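The source may report more compounds than this note shows. Statements on the series, on what has been measured and on what is new or still open speak of the compounds shown alone.

In an assay on HEK293 cells for inhibition of Steryl-sulfatase (Homo sapiens), tested at 0.1 uM (on this read-out lower numbers stand for a weaker effect and higher numbers for a stronger effect at the one concentration tested), compound 1, whose structure is `CCN(Cc1cccnc1)c1ccc(C(=O)N2CCc3ccc(OS(N)(=O)=O)cc3C2)cc1`, gives 35.7%, the highest of the three numbers recorded. Compound 3, with structure `CN(CCN1CCCCC1)c1cccc(C(=O)N2CCc3ccc(OS(N)(=O)=O)cc3C2)c1`, gives 24.5% in this assay, and the gap between the two lies beyond the scatter. Compound 2, with structure `NS(=O)(=O)Oc1ccc2c(c1)CN(C(=O)c1cccc(N3CCC(N4CCCCC4)CC3)c1)CC2`, gives 0% in this assay, the lowest of the three and again beyond the scatter from compound 1.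

Compound 4, whose structure is `CCN(Cc1ccncc1)c1ccc(C(=O)N2CCc3ccc(OS(N)(=O)=O)cc3C2)cc1`, has not yet been measured. It differs from compound 1 only in the following way: pyridin-4-yl in place of pyridin-3-yl on a saturated chain carbon bound to a nitrogen on an aromatic ring The two compounds keep the same atoms and the same core, the change being limited to the pyridyl attachment.

For the measured compounds named here, no measured pair shows the effect of such a change, so no step size can be read from the data. Compound 4 is expected to behave much like compound 1, with a step from compound 1 to compound 4 of a number 4.7 percentage points lower from compound 1 to compound 4 (within the scatter), which would be within the scatter. On that basis compound 4 is estimated to give 31% in this assay, with a range from 12% to 50%.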

Compound 4, a percentage reported as inhibition, at one concentration (the size of the read-out at that concentration, not a potency): 47%
For compound 4 the middle estimate is 16 percentage points below the measured one; the range from low to high includes it.
By their numbers in this assay, from the lowest: compound 2; then compound 3; then compound 1; then compound 4.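

In this assay the change to pyridin-4-yl in place of pyridin-3-yl on a saturated chain carbon bound to a nitrogen on an aromatic ring gives a number 11.3 percentage points higher from compound 1 to compound 4 (beyond the scatter). This is the only pair shown that differs in one place, and it shows that the read-out at this position depends on how the pyridine ring is attached, even though the atoms and the counts of donors and acceptors stay the same. Nothing given here bears on what lies behind this modest step.

The compounds shown leave open how pyridin-2-yl or a plain phenyl ring would fare at the same place. They also leave open whether the step from pyridin-3-yl to pyridin-4-yl would hold with a methyl or a longer chain in place of the ethyl on that nitrogen.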